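The source may report more compounds than this note shows. Statements on the series, on what has been measured and on what is new or still open speak of the compounds shown alone.

Measured compounds in an assay on isolated protein for inhibition of G protein-coupled receptor kinase 5 (Homo sapiens), read by TR-FRET, with stated times of 10 min and 1 h; on this read-out higher numbers stand for weaker inhibition and lower numbers for stronger inhibition:
compound 1 `CN(c1ccccc1)c1ccc2oc(-c3cc(-c4cnn(C5CCNCC5)c4)cnc3N)nc2c1`, 5050 nM;
compound 2 `Nc1ncc(-c2cnn(C3CCNCC3)c2)cc1-c1nc2ccc(Nc3cc(C(F)(F)F)cc(C(F)(F)F)c3)cc2o1`, 4200 nM;
compound 3 `Nc1ncc(-c2cnn(C3CCNCC3)c2)cc1-c1nc2ccc(-c3cn[nH]c3)cc2o1`, 1780 nM.

Compound 3 stands lowest of the three numbers; compound 2 sits a step higher that lies beyond the usual scatter, and compound 1 higher still. Compound 4 `Nc1ncc(-c2cnn(C3CCNCC3)c2)cc1-c1nc2ccc(-c3ccc4[nH]ncc4c3)cc2o1` differs from compound 3 in one place: 1H-indazol-5-yl in place of 1H-pyrazol-4-yl on an aromatic carbon. Among the measured compounds shown here, no step between measured compounds tells what this exchange does, so the expectation rests on compound 3 alone. A step in this assay of no more than the usual scatter, if anything toward a lower number, is expected, described by a 1.4-fold lower number from compound 3 to compound 4 (0.14 log units; within the scatter). Compound 4 is therefore expected to give about 1300 nM in this assay, with a likely range from 450 nM to 3800 nM.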

Compound 4, half-maximal inhibitory concentration: 1140 nM
Beside the measured number, compound 4's estimate is 1.1-fold (0.06 log units) above it; the range from low to high includes it.
By their numbers in this assay, from the lowest: compounds 4 and 3 (each within the scatter of the next); then compounds 2 and 1 (each within the scatter of the next).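

In this assay, putting 1H-indazol-5-yl in place of 1H-pyrazol-4-yl on this aromatic carbon gives a 1.6-fold lower number from compound 3 to compound 4 (0.19 log units; within the scatter), so this position accepts the added six-membered aromatic ring of carbon only, and the two compounds cannot be told apart on this read-out. Nothing measured here bears on why the larger group is accepted. Still open, as far as these compounds go, is whether a carboxylic acid or a morpholine ring on this carbon would give a step beyond the scatter. From the compounds shown here alone, whether a methyl group on the indazole nitrogen would do so also remains open.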